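The source may hold more compounds than are shown below. What is called first, only, known or untested is meant among the compounds shown, and "the series" means these compounds.

Compound 3, `CNC(=O)[C@@]12C[C@@H]1[C@@H](n1cnc3c(NC)nc(C#Cc4cccnc4)nc31)[C@H](O)[C@@H]2O`, stands second highest of the three numbers in an assay on CHO cells for displacement of a labelled ligand from adenosine receptor A3 (Homo sapiens), read by scintillation counting, with a stated time of 60 min (a lower number here means a stronger inhibitor, a higher number a weaker inhibitor), where compound 3 gives 2.15 nM. Compound 1, `CNC(=O)[C@@]12C[C@@H]1[C@@H](n1cnc3c(NC)nc(C#Cc4ccccc4OC)nc31)[C@H](O)[C@@H]2O`, gives 0.77 nM, and compound 2, `CNC(=O)[C@@]12C[C@@H]1[C@@H](n1cnc3c(NC)nc(C#Cc4cccc(C(F)(F)F)c4)nc31)[C@H](O)[C@@H]2O`, gives 3.39 nM. The steps among them ran a 2.8-fold higher number from compound 1 to compound 3 (0.45 log units; beyond the scatter) and a 1.6-fold lower number from compound 2 to compound 3 (0.20 log units; within the scatter). Compound 4, `CNC(=O)[C@@]12C[C@@H]1[C@@H](n1cnc3c(NC)nc(C#Cc4cccnn4)nc31)[C@H](O)[C@@H]2O`, differs from compound 3 by pyridazin-3-yl in place of pyridin-3-yl on a triple-bonded carbon. Within the data shown here, no measured step exchanges one six-membered aromatic ring for another of the same size at this position; the closest comparison is a 1.6-fold lower number from compound 2 to compound 3 (0.20 log units; within the scatter), which lay within the scatter, while both departures from compound 1 were modest. The expected step is therefore a 1.4-fold higher number from compound 3 to compound 4 (0.14 log units; within the scatter), with no change beyond the scatter. Compound 4 is estimated at 3 nM, between 1.2 nM and 8 nM.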

Compound 4, inhibition constant: 3.53 nM
Compound 4: middle estimate off by 1.2-fold (0.07 log units), on the low side, and the stated range covers the measured number.
By their numbers in this assay, from the lowest: compound 1; then compounds 3, 2 and 4 (each within the scatter of the next).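

In this assay, the change from one ring nitrogen to two at this position, pyridazin-3-yl in place of pyridin-3-yl, gives a 1.6-fold higher number from compound 3 to compound 4 (0.22 log units; within the scatter) and so stays within the scatter. The exchange with 3-(trifluoromethyl)phenyl also stays within it, at a 1.0-fold higher number from compound 2 to compound 4 (0.02 log units; within the scatter), so these three groups cannot be told apart here. Only 2-methoxyphenyl stands apart, with a 4.6-fold higher number from compound 1 to compound 4 (0.66 log units; beyond the scatter) and a third modest departure from compound 1, this one beyond the scatter.

Nothing given here explains that difference. Open too, as far as these compounds go, is how an amine or a carboxylic acid on this ring would read.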